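The compounds below may be only part of what the source reports. "The series", "measured", "known", "first", "only" and "open" are said of these compounds alone.

Measured in a functional assay on NCI-H1975 cells (Homo sapiens) for antiproliferative activity; a lower number here means a stronger inhibitor, a higher number a weaker inhibitor:
- compound 1 `Cc1c2c(n3c1CCNC[C@@H](C)[C@H](C)Nc1cc-3ccc1C(N)=O)CC(C)(C)CC2=O`: 27 nM
- compound 2 `CC(=O)N1CCCc2c(C)c3c(n2-c2ccc(C(N)=O)c(c2)N[C@@H](C)[C@@H]1C)CC(C)(C)CC3=O`: 20 nM
- compound 3 `CC[C@H](N)C(=O)N1CCc2c(C)c3c(n2-c2ccc(C(N)=O)c(c2)N[C@@H](C)[C@H](C)C1)CC(C)(C)CC3=O`: 41 nM

Compound 3 stands close to compound 1, as the measured step shows: a 1.5-fold higher number from compound 1 to compound 3 (0.18 log units; within the scatter). Its number lies above that of compound 2, and the gap between those two values falls just beyond the usual scatter.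

Compound 4 `Cc1c2c(n3c1CCN(C(=O)[C@H](C)O)C[C@@H](C)[C@H](C)Nc1cc-3ccc1C(N)=O)CC(C)(C)CC2=O` is the next structure in the series. It differs from compound 3 in one place: 1-hydroxyethyl in place of 1-aminopropyl on a carbonyl carbon. In words, 1-hydroxyethyl stands in place of 1-aminopropyl on a carbonyl carbon, the other neighbour being an amide-type nitrogen in a ring. Cut one bond further out, the same difference reads (1-aminopropyl)carbonyl to (1-hydroxyethyl)carbonyl.

For the measured compounds named here, only one measured step bears on this change, the one that placed (1-aminopropyl)carbonyl on the ring nitrogen of compound 1. Going by the values given here, no measured compound carries (1-hydroxyethyl)carbonyl, so the data give no direction. Among the compounds with values here, the expectation in this assay is therefore a change no larger than the scatter, because a 1.5-fold higher number from compound 1 to compound 3 (0.18 log units; within the scatter) was the only change measured at this nitrogen. The expected step is a 1.2-fold lower number from compound 3 to compound 4 (0.07 log units; within the scatter). For compound 4 the estimate is 35 nM, with an expected range of 15 nM to 85 nM.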

Compound 4, half-maximal inhibitory concentration: 52 nM
For compound 4 the middle estimate is 1.5-fold (0.17 log units) below the measured one; measured number inside the range.
By their numbers in this assay, from the lowest: compounds 2, 1, 3 and 4 (each within the scatter of the next, the first and the last beyond it).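

In this assay the second acyl group on this ring nitrogen gives a 1.9-fold higher number from compound 1 to compound 4 (0.28 log units; within the scatter), so (1-hydroxyethyl)carbonyl, like (1-aminopropyl)carbonyl before it, leaves the number within the scatter of the compound with hydrogen on that nitrogen. The exchange of the two groups on the carbonyl carbon gives a 1.3-fold higher number from compound 3 to compound 4 (0.10 log units; within the scatter), which does not separate them, so the nitrogen of 1-aminopropyl is not required to keep the number in this range, a point that compound 3 alone could not show. Nothing at hand accounts for these numbers.

The exchange replaces nitrogen with oxygen and also shortens the group from four heavy atoms to three, so the compounds shown cannot separate those two differences, and 1-aminoethyl on the same carbonyl carbon would be the group to do so. On these data alone, it also remains open whether a carboxylic acid or a longer chain on that carbonyl carbon would stay within the scatter of compound 1, or whether either would move the number beyond it.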